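The source may hold more compounds than are shown below. What is called first, only, known or untested is meant among the compounds shown, and "the series" means these compounds.

Measured so far in an ADME assay on THP-1 cells (Homo sapiens) for cytotoxicity; a lower number here means a stronger inhibitor, a higher number a weaker inhibitor:
- compound 1 `COc1ccccc1-c1nnc(-c2ccc(C(=O)N/N=C/c3cc(O)ccc3O)cc2)o1`: 100000 nM
- compound 2 `COc1ccccc1-c1nnc(-c2ccc(C(=O)N/N=C/c3ccc(F)cc3)cc2)o1`: 427000 nM
- compound 3 `COc1ccccc1-c1nnc(-c2ccc(C(=O)N/N=C/c3ccc(O)c(O)c3)cc2)o1`: 100000 nM

Compound 3 stands level with compound 1, the two together giving the lowest numbers of the three; the step of no change at the digits printed from compound 1 to compound 3 (within the scatter) is within the scatter. Compound 2 sits apart, with a 4.3-fold lower number from compound 2 to compound 3 (0.63 log units; beyond the scatter) lying beyond the scatter.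

Compound 4 `COc1ccccc1-c1nnc(-c2ccc(C(=O)N/N=C/c3cccnc3)cc2)o1` is the next structure to be measured. It differs from compound 3 by pyridin-3-yl in place of 3,4-dihydroxyphenyl on a carbon with a double bond to nitrogen. The step that bears on this change most is a 4.3-fold lower number from compound 2 to compound 3 (0.63 log units; beyond the scatter): an aryl group without hydroxyls, read in the other direction, gave a modest rise in the number, while swapping one dihydroxyphenyl for another, no change at the digits printed from compound 1 to compound 3 (within the scatter), gave nothing beyond the scatter. Compound 4 likewise carries no hydroxyl on that ring, so a modest rise relative to compound 3 is expected, of about the size seen between compound 2 and the hydroxylated pair, a 2.5-fold higher number from compound 3 to compound 4 (0.40 log units; beyond the scatter). The estimate for compound 4 in this assay is therefore 250000 nM, with a range of 100000 nM to 600000 nM.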

Compound 4, half-maximal inhibitory concentration: 167000 nM
The estimate for compound 4 lay 1.5-fold (0.18 log units) above the measured number, within the range that was stated.
By their numbers in this assay, from the lowest: compounds 1, 3 and 4 (each within the scatter of the next); then compound 2.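

In this assay, pyridin-3-yl on a carbon with a double bond to nitrogen stays within the scatter of both dihydroxyphenyl compounds (a 1.7-fold higher number from compound 3 to compound 4 (0.22 log units; within the scatter); a 1.7-fold higher number from compound 1 to compound 4 (0.22 log units; within the scatter)), so a ring with 0 hydrogen-bond donors can sit level with them. Compound 2 alone now goes with the earlier link between a ring without hydroxyls and a higher number, and compound 4 goes against it, with a step beyond the scatter separating the two rings without hydroxyls (a 2.6-fold lower number from compound 2 to compound 4 (0.41 log units; beyond the scatter)). Nothing available on these compounds accounts for this difference.

On these data alone, whether the fluorine of compound 2 matters remains open, as unsubstituted phenyl on the same carbon would test it. As far as these compounds go, whether an amine or a carboxylic acid on that ring keeps the number level with compound 4 also remains open.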